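Notes on the series: from compound 3 to compound 4

The source may hold more compounds than are shown below. What is called first, only, known or untested is meant among the compounds shown, and "the series" means these compounds.

Three compounds share one core and differ only in the group on a saturated chain carbon bound to a nitrogen on an aromatic ring. In a functional assay on cells for positive allosteric modulation of G-protein coupled receptor 68 (Homo sapiens), read by a luciferase reporter and cAMP accumulation, with a stated time of 30 min, at pH 6.8 and pH 8.3, in the presence of a further agent that is not named here (a lower number here means a less potent compound, a higher number a more potent compound, by a factor of ten per unit of this negative logarithm), compound 1 `Nc1nc(NCc2ccc(Cl)cc2)nc(-c2ccccc2CO)n1` gives 5.22. Compound 2 `Cc1ccccc1CNc1nc(N)nc(-c2ccccc2CO)n1` gives 4.7, and compound 3 `Cc1ccc(CNc2nc(N)nc(-c3ccccc3CO)n2)cc1` gives 4.38. Compound 3 stands lowest of the three: the step of a number 0.84 log units lower from compound 1 to compound 3 (beyond the scatter) and the step of a number 0.32 log units lower from compound 2 to compound 3 (beyond the scatter) both lie beyond the scatter, as does the step of a number 0.52 log units lower from compound 1 to compound 2 (beyond the scatter).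

Compound 4 `Nc1nc(NCCCc2ccccc2)nc(-c2ccccc2CO)n1` is not yet measured. It differs from compound 3 by phenethyl in place of 4-methylphenyl on a saturated chain carbon bound to a nitrogen on an aromatic ring. None of the three measured steps concerns a change of this kind; each of them exchanges a chloro for a methyl on the aryl ring or moves the methyl, and each gave only a modest step. Nothing measured shows how a longer chain behaves, so the expectation rests on the small size of the steps seen so far. For compound 4 a step of about a number 0.12 log units higher from compound 3 to compound 4 (within the scatter) is expected, that is, little change in either direction. Compound 4 is therefore estimated at 4.5 in this assay, with a range from 3.9 to 5.1.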

Compound 4, negative logarithm of the antagonist equilibrium constant: 5.22
Estimate against measurement, compound 4: 0.72 log units below, outside the stated range (above it).
By their numbers in this assay, from the lowest: compound 3; then compound 2; then compounds 1 and 4 (each within the scatter of the next).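

In this assay the group at this position, on a saturated chain carbon bound to a nitrogen on an aromatic ring, matters more than the exchanges on the aryl ring alone had shown: phenethyl in place of 4-methylphenyl gives a number 0.84 log units higher from compound 3 to compound 4 (beyond the scatter) and phenethyl in place of 2-methylphenyl gives a number 0.52 log units higher from compound 2 to compound 4 (beyond the scatter) in the same direction. Against the chloro compound the picture differs, with no change at the digits printed from compound 1 to compound 4 (within the scatter) for phenethyl in place of 4-chlorophenyl, so a group with no substituent on its ring is not separated from compound 1, and a chloro on the ring is not the only way to that level among these four compounds. No measurement in hand bears on why phenethyl reads as it does here.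

From the compounds shown here alone, in these compounds the change of chain and the loss of the ring substituent arrive together, so their separate contributions stay open; an unsubstituted benzyl group, or a chloro on the ring of the phenethyl group, would bear on that. Also open, going by these compounds, is how a longer chain, or an amine or a carboxylic acid on the chain in place of the phenyl ring, would read in this assay at this position.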